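From trifluoromethoxy to amino: an expectation for compound 3

The source may report more compounds than this note shows. Statements on the series, on what has been measured and on what is new or still open speak of the compounds shown alone.

Compound 1 `CCc1ccc(NC(=O)Nc2cc(C)nc3ccccc23)cc1` 3300 nM
Compound 2 `Cc1cc(NC(=O)Nc2ccc(OC(F)(F)F)cc2)c2ccccc2n1` 300 nM
Compound 3 `Cc1cc(NC(=O)Nc2ccc(N)cc2)c2ccccc2n1` not yet measured

For the measured compounds named here, in a physicochemical assay for solubility, at pH 7.4 (a higher number here means a more soluble compound, a lower number a less soluble compound), compound 2 gives 300 nM as the lower of the two numbers so far, and compound 1 is its only neighbour. Compound 3 has amino in place of trifluoromethoxy on an aromatic carbon, para to a large group, and the count of that change is amino in place of trifluoromethoxy on an aromatic carbon in full. Going by the values given here, one measured step bears on it. The large step of an 11-fold lower number from compound 1 to compound 2 (1.04 log units; beyond the scatter) came with trifluoromethoxy in place of ethyl, beyond the scatter. Among the compounds with values here, no measured compound carries amino, so this step is only a partial guide. Now that trifluoromethoxy leaves, a large step of similar size toward a higher number is expected, namely a 17-fold higher number from compound 2 to compound 3 (1.22 log units; beyond the scatter) in this assay as estimated here. For compound 3 the estimated value is 5000 nM with an expected range from 1200 nM to 20000 nM as its bounds.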

Compound 3, solubility: 18500 nM
Estimate against measurement, compound 3: 3.7-fold (0.57 log units) below; measured number inside the range.
By their numbers in this assay, from the lowest: compound 2; then compound 1; then compound 3.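

In this assay the aromatic carbon para to a large group now proves able to move the number upward as well as downward, with amino in place of trifluoromethoxy giving a 62-fold higher number from compound 2 to compound 3 (1.79 log units; beyond the scatter) on the otherwise shared structure. Amino in place of ethyl gives a 5.6-fold higher number from compound 1 to compound 3 (0.75 log units; beyond the scatter) in the same direction, so ethyl does not mark the top of what this position allows. Compound 3 holds the highest number of the three, with both its steps beyond the scatter, and the groups at this place rank trifluoromethoxy, ethyl, amino from the lowest number.

As far as these compounds go, whether a hydroxyl, a methylamino group or a carboxylic acid at this place would follow amino stays open. So does whether amino would give a similar step on a different core. Nothing measured here speaks to why the number moves with these groups.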